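This account rests on a few compounds, and the source may have more. Where it says the series, first, only, none or still open, it means among the compounds named here.

In a functional assay on K562 cells (Homo sapiens) for cytotoxicity, read by ELISA, with a stated time of 4 days (a higher number here means a weaker inhibitor, a lower number a stronger inhibitor), two compounds sharing one core have been measured so far. Within the data shown here, compound 1 `Cc1ccc(-c2cc(-c3ccoc3)cc(-c3ccc(Cl)s3)n2)o1` gives 12700 nM and compound 2 `Clc1ccc(-c2cc(-c3ccoc3)cc(-c3ccc(Cl)s3)n2)cc1` gives 19600 nM, so compound 2 stands level with its only neighbour, within the scatter. Compound 3 `Clc1ccc(-c2cc(-c3ccc(Cl)o3)cc(-c3ccc(Cl)s3)n2)cc1` keeps the 4-chlorophenyl group of compound 2 and changes the group opposite the ring nitrogen, with 5-chlorofuran-2-yl in place of furan-3-yl on an aromatic carbon. Among the measured compounds shown here, only one measured step exists, a 1.5-fold higher number from compound 1 to compound 2 (0.19 log units; within the scatter), and it was small. For the measured compounds named here, that step lies at a different place, so it bears on this change only indirectly, and no measurement yet tests the place that changes here. From the compounds shown here alone, no step beyond the scatter is therefore expected in this assay, and the direction stays open. The expected step is a 1.4-fold lower number from compound 2 to compound 3 (0.15 log units; within the scatter). For compound 3 the estimated value is 14000 nM, with an expected range from 5000 nM to 35000 nM.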

Compound 3, half-maximal inhibitory concentration: 19300 nM
Estimate against measurement, compound 3: 1.4-fold (0.14 log units) below, and the stated range covers the measured number.
By their numbers in this assay, from the lowest: compounds 1, 3 and 2 (each within the scatter of the next).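

Among these compounds, this is the first measured change at the place opposite the ring nitrogen, and in this assay putting 5-chlorofuran-2-yl in place of furan-3-yl gives a 1.0-fold lower number from compound 2 to compound 3 (0.01 log units; within the scatter) with the 4-chlorophenyl group held fixed. The swap does two things at once, shifting the point where the furan ring attaches and adding a chlorine, and together they leave the number level, so the data cannot separate the two. Nothing measured here explains why the two groups read alike.

Plain furan-2-yl at this place, with no chlorine, would be the group that pulls the two alterations apart. From the compounds shown here alone, every group compared so far is an aromatic ring, so how an amine, a carboxylic acid or a longer alkyl chain would read opposite the ring nitrogen stays open.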